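Aryl replacement on the amide-type nitrogen of the shared core

The source may hold more compounds than are shown below. What is called first, only, known or untested is meant among the compounds shown, and "the series" means these compounds.

Measured compounds:
compound 1 `O=C(Nc1ccccc1C(F)(F)F)N1CCC(c2nc(-c3ccc4ccccc4n3)no2)CC1` — 700 nM
compound 2 `Cc1ccccc1NC(=O)N1CCC(c2nc(-c3ccc4ccccc4n3)no2)CC1` — 440 nM
compound 3 `O=C(Nc1ncccc1Cl)N1CCC(c2nc(-c3ccc4ccccc4n3)no2)CC1` — 2800 nM

In a functional assay on Shh Light II cells (Mus musculus) for inhibition, read by a luciferase reporter (on this read-out higher numbers stand for weaker inhibition and lower numbers for stronger inhibition), compound 3 gives the highest of the three numbers: the step of a 4.0-fold higher number from compound 1 to compound 3 (0.60 log units; beyond the scatter) and the step of a 6.4-fold higher number from compound 2 to compound 3 (0.80 log units; beyond the scatter) both lie beyond the scatter, whereas a 1.6-fold lower number from compound 1 to compound 2 (0.20 log units; within the scatter) stays within it, so compound 1 and compound 2 are not ordered against each other. Compound 4 `O=C(Nc1cccc2cccnc12)N1CCC(c2nc(-c3ccc4ccccc4n3)no2)CC1` is the next member and differs from compound 3 in one place: quinolin-8-yl in place of 3-chloropyridin-2-yl on an amide-type nitrogen.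

The two steps that bear on this change are the ones into compound 3, since each of them exchanges the group on the same amide-type nitrogen. Both show a carbon-only aromatic ring there giving a lower number than the 3-chloropyridin-2-yl, by a modest margin. Among the compounds with values here, the entering quinolin-8-yl carries a carbon-only ring together with a ring with one hetero atom, and no measured compound carries a bicyclic group on that nitrogen, so the expectation rests on those two steps alone. Compound 4 is therefore expected to move back toward compound 1 and compound 2, a modest drop, a 3.5-fold lower number from compound 3 to compound 4 (0.54 log units; beyond the scatter). In this assay compound 4 is estimated at 800 nM, within a range from 250 nM to 2500 nM.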

Compound 4, half-maximal inhibitory concentration: 1400 nM
The estimate for compound 4 lay 1.8-fold (0.24 log units) below the measured number, and the stated range covers the measured number.
By their numbers in this assay, from the lowest: compounds 2, 1, 4 and 3 (each within the scatter of the next, the first and the last beyond it).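

In this assay, within the data shown here, the step of a 2.0-fold lower number from compound 3 to compound 4 (0.30 log units; within the scatter) stays within the scatter and the step of a 2.0-fold higher number from compound 1 to compound 4 (0.30 log units; within the scatter) stays within it too, so quinolin-8-yl, the first group with two rings on the amide-type nitrogen, cannot be told apart there from either 3-chloropyridin-2-yl or 2-(trifluoromethyl)phenyl. Among these compounds, only the step of a 3.2-fold higher number from compound 2 to compound 4 (0.50 log units; beyond the scatter) lies beyond the scatter, and it is modest, so the second ring costs no more than a modest step against any of the three earlier groups, and compound 4 sits within the span from compound 1 to compound 3 without being ordered against either end. Nothing at hand accounts for these numbers.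

Still open, as far as these compounds go, is whether the ring nitrogen of quinolin-8-yl matters to the number, which naphthalen-1-yl on the same nitrogen would test, and whether the gap between compound 3 and the phenyl compounds follows the ring nitrogen, which 2-chlorophenyl would test. Also open, from the compounds shown here alone, is how a non-aromatic group on that nitrogen, such as cyclohexyl or a longer alkyl chain, would read in this assay against these aromatic groups.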